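From a Limit: Another Change on the Carbonyl Carbon

This account rests on a few compounds, and the source may have more. Where it says the series, first, only, none or still open, it means among the compounds named here.

In a functional assay on HepG2 cells (Homo sapiens) for antiproliferative activity, read by MTT assay, with a stated time of 48 h (on this read-out lower numbers stand for stronger inhibition and higher numbers for weaker inhibition), compound 1 (`CCn1c(C(=O)NCCCN(C)C)ccc1C(CC)(CC)c1ccc(OCCC(O)(CC)CC)c(C)c1`) gives 110 nM. Compound 2 (`CCn1c(C(=O)NCC#N)ccc1C(CC)(CC)c1ccc(OCCC(O)(CC)CC)c(C)c1`) gives > 50000 nM, which is a limit. Compound 3 (`CCC(C)C(NC(=O)c1ccc(C(CC)(CC)c2ccc(OCCC(O)(CC)CC)c(C)c2)n1CC)C(=O)OC`) gives > 50000 nM, also a limit and no number. It therefore stands at the limit of > 50000 nM in this assay, at which 2 of the 3 values shown sit. Compound 4 (`CCn1c(C(=O)N(C)CC(=O)O)ccc1C(CC)(CC)c1ccc(OCCC(O)(CC)CC)c(C)c1`) changes compound 3 on a carbonyl carbon, where (carboxymethyl)(methyl)amino enters: a group of 6 heavy atoms (3 carbon, 1 nitrogen, 2 oxygen; no ring) in place of a group of 10 heavy atoms (7 carbon, 1 nitrogen, 2 oxygen; no ring), on a carbonyl carbon. Two large measured steps bear on this change, an at least 450-fold higher number from compound 1 to compound 2 (2.65 log units; beyond the scatter) and an at least 450-fold higher number from compound 1 to compound 3 (2.65 log units; beyond the scatter). Both end at the limit, so neither shows how far a compound lies past it. No step beyond the scatter is therefore expected, and no direction can be given. The expected step is a number no higher from compound 3 to compound 4 (the limit leaves the size open). The estimated value for compound 4 is 50000 nM, with an expected range from 15000 nM to 100000 nM.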

Compound 4, half-maximal inhibitory concentration: 5710 nM
For compound 4 the middle estimate is 8.8-fold (0.94 log units) above the measured one; measured number outside the range, below it.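

On the carbonyl carbon, (carboxymethyl)(methyl)amino brings a compound back from the limit in this assay, giving an at least 8.7-fold lower number from compound 3 to compound 4 (0.94 log units; beyond the scatter) and an at least 8.7-fold lower number from compound 2 to compound 4 (0.94 log units; beyond the scatter). As far as these compounds go, compound 2 and compound 3 each stand at a limit and not at a number, so the full size of these steps stays open: the limit of > 50000 nM in this assay, at which 2 of the 4 values shown sit. The (3-(dimethylamino)propyl)amino group still gives the lower number, with a 52-fold higher number from compound 1 to compound 4 (1.72 log units; beyond the scatter).

The compounds shown leave open whether (carboxymethyl)amino, without the methyl, or a longer chain ending in a carboxylic acid would hold this level. They also leave open how a chain ending in morpholine would compare with compound 1.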